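From 3-chlorophenyl to 4-methoxyphenyl on the shared core

The compounds below may be only part of what the source reports. "The series", "measured", "known", "first", "only" and "open" are said of these compounds alone.

Measured in a functional assay on HeLa cells (Homo sapiens) for antiproliferative activity, read by sulforhodamine B assay, with a stated time of 72 h; a lower number here means a stronger inhibitor, a higher number a weaker inhibitor:
- compound 1 `Fc1ccccc1NC(=S)N/N=C/c1ccc2ccccc2n1`: > 100000 nM (a limit)
- compound 2 `S=C(NCc1ccccc1)N/N=C/c1ccc2ccccc2n1`: 62800 nM
- compound 3 `S=C(N/N=C/c1ccc2ccccc2n1)Nc1cccc(Cl)c1`: 52500 nM

Compound 3, at 52500 nM, stands level with compound 2, at 62800 nM. The step between them is a 1.2-fold lower number from compound 2 to compound 3 (0.08 log units; within the scatter). Compound 1 gives no number, only a limit of this assay: > 100000 nM. The steps that start from that limit are an at least 1.5-fold lower number from compound 1 to compound 2 (0.20 log units; that floor lies within the scatter) and an at least 1.9-fold lower number from compound 1 to compound 3 (0.27 log units; that floor lies within the scatter).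

Compound 4 `COc1ccc(NC(=S)N/N=C/c2ccc3ccccc3n2)cc1` has not yet been measured. It carries 4-methoxyphenyl in place of 3-chlorophenyl on an amide-type nitrogen, and the counted difference is 4-methoxyphenyl in place of 3-chlorophenyl on an amide-type nitrogen. All three measured steps change the group at this same place, and none is shown beyond the scatter. None of them tests a methoxy group, so they are only an indirect guide. On this basis, no step beyond the scatter is expected in this assay, in either direction. Compound 1 also leaves open the chance that compound 4 reads only as a limit.

The expected change is a 1.1-fold lower number from compound 3 to compound 4 (0.02 log units; within the scatter). For compound 4 the estimated value is 50000 nM, with an expected range of 20000 nM to 100000 nM.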

Compound 4, half-maximal inhibitory concentration: 72600 nM
For compound 4 the middle estimate is 1.5-fold (0.16 log units) below the measured one; the measured number falls inside the stated range.
By their numbers in this assay, from the lowest: compounds 3, 2 and 4 (each within the scatter of the next). At a limit, above all of these: compound 1.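

In this assay, going by these compounds alone, 4-methoxyphenyl on an amide-type nitrogen whose other neighbour is the thiocarbonyl carbon brings a methoxy group to this place, which none of the earlier compounds carried, and the steps stay within the scatter: a 1.4-fold higher number from compound 3 to compound 4 (0.14 log units; within the scatter), and a 1.2-fold higher number from compound 2 to compound 4 (0.06 log units; within the scatter). Exchanging 3-chlorophenyl, with no hydrogen-bond acceptor counted, for 4-methoxyphenyl, with one, therefore gives no step beyond the scatter here, and the step of an at least 1.3-fold lower number from compound 1 to compound 4 (0.13 log units; that floor lies within the scatter) offers only a floor, so compound 4 is not separated from compound 1 either. Compound 1 remains a limit of the assay and not a number: the limit of > 100000 nM in this assay, at which 1 of the 4 values shown sits.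

On these data alone, compounds 2, 3 and 4 all lie within the scatter of one another, so it remains open whether any group at this place can move the number beyond the scatter, for instance a group bearing an amine or a carboxylic acid, or a longer chain. The compounds shown also leave open how a change to the shared core, rather than at this nitrogen, would read in this assay.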